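From amino to thiophen-2-yl on the shared core

This account rests on a few compounds, and the source may have more. Where it says the series, first, only, none or still open, it means among the compounds named here.

Compound 1 `CN(C)c1ncnc2[nH]cc(Sc3cccs3)c12`: 35300 nM
Compound 2 `CNc1ncnc2[nH]cc(Sc3cccs3)c12`: 26200 nM
Compound 3 `Nc1ncnc2[nH]cc(Sc3cccs3)c12`: 20300 nM

All three values come from a functional assay on CEM-DNR cells (Homo sapiens), read by MTT assay, with a stated time of 3 days; a higher number here means a weaker inhibitor, a lower number a stronger inhibitor. Compound 3 cannot be separated from its two neighbours on these numbers. The measured steps are a 1.3-fold lower number from compound 2 to compound 3 (0.11 log units; within the scatter) and a 1.7-fold lower number from compound 1 to compound 3 (0.24 log units; within the scatter), and neither stands out from the scatter. Removing methyl from the nitrogen also leaves the reading within the scatter, as a 1.3-fold lower number from compound 1 to compound 2 (0.13 log units; within the scatter) shows.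

The next structure, compound 4 `c1csc(Sc2c[nH]c3ncnc(-c4cccs4)c23)c1`, makes a larger change at the same carbon: thiophen-2-yl in place of amino on an aromatic carbon. In words, this is thiophen-2-yl in place of amino on an aromatic carbon. The three measured steps bear on this carbon, but they only trim methyl from the nitrogen, and none of them puts thiophen-2-yl there. They therefore offer a flat background and no direct guide to this exchange. With no measured step beyond the scatter, no clear shift is expected in this assay in either direction, although the uncertainty is wide. The estimated step is a 1.4-fold lower number from compound 3 to compound 4 (0.13 log units; within the scatter). Compound 4 is estimated at 15000 nM, with an expected range from 4000 nM to 50000 nM.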

Compound 4, half-maximal inhibitory concentration: 17700 nM
Compound 4: middle estimate off by 1.2-fold (0.07 log units), on the low side, within the range that was stated.
By their numbers in this assay, from the lowest: compounds 4, 3, 2 and 1 (each within the scatter of the next).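

At this aromatic carbon, next to the ring nitrogen, the earlier compounds had only shown methyl being trimmed from the nitrogen, whereas here the whole amino group gives way to a thiophen-2-yl ring. In this assay, a 1.1-fold lower number from compound 3 to compound 4 (0.06 log units; within the scatter) and a 1.5-fold lower number from compound 2 to compound 4 (0.17 log units; within the scatter) and a 2.0-fold lower number from compound 1 to compound 4 (0.30 log units; within the scatter) all lie within the scatter, the last of them even though it spans the widest exchange in the set. The carbon therefore accepts an aromatic ring with no nitrogen attached to the core at this point, and with 0 hydrogen-bond donors in the entering group, without the reading leaving the scatter of the three amines, though nothing available accounts for this flat result.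

The compounds shown leave open whether a different kind of group at this carbon, such as a carboxylic acid, a chlorine atom or a longer alkyl chain, would move the reading beyond the scatter. All four also carry the same thiophene bound through sulfur, which leaves open what a phenyl ring or an amine would do in its place.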